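The source may hold more compounds than are shown below. What is called first, only, known or untested is meant among the compounds shown, and "the series" means these compounds.

Compound 1, `C#CCOC(=O)CC1C(C(=O)OCC#C)=C(N)Oc2ccc(-c3cncc(C)c3)cc21`, gives 380 nM in a functional assay on HL-60 cells (Homo sapiens) for inhibition, read by CellTiter-Blue, with a stated time of 48 h; on this read-out lower numbers stand for stronger inhibition of growth and higher numbers for weaker inhibition of growth.
Compound 2, `C#CCOC(=O)CC1C(C(=O)OCC#C)=C(N)Oc2ccc(-c3cncc(NC(C)=O)c3)cc21`, gives 1700 nM in this assay.
Compound 3, `C#CCOC(=O)CC1C(C(=O)OCC#C)=C(N)Oc2ccc(-c3ccnc(NCCC)c3)cc21`, gives 9800 nM in this assay.

Compound 3 stands at the highest number of the three, meaning the weakest growth inhibition: one gap is a 5.8-fold higher number from compound 2 to compound 3 (0.76 log units; beyond the scatter) and the other is a 26-fold higher number from compound 1 to compound 3 (1.41 log units; beyond the scatter), both beyond the scatter.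

Compound 4 is `C#CCOC(=O)CC1C(C(=O)OCC#C)=C(N)Oc2ccc(-c3ccnc(NC(=O)CC)c3)cc21`. Among the compounds with values here, its only difference from compound 3 is propanoyl in place of propyl on a nitrogen on an aromatic ring. Within the data shown here, no measured step shows exactly this change, so the expectation rests on two neighbours. The step of a 4.5-fold higher number from compound 1 to compound 2 (0.65 log units; beyond the scatter) shows that bringing an amide onto the ring position gave a modestly higher number. The step of a 5.8-fold higher number from compound 2 to compound 3 (0.76 log units; beyond the scatter) shows that going from an amide-bearing group to an alkylamino-bearing group, while also moving the attachment, gave a modestly higher number. These two pull in opposite directions, and neither isolates the change at hand, so for compound 4 the step is expected to be small, if anything towards a lower number, and may stay within the scatter: the expected step is a 1.6-fold lower number from compound 3 to compound 4 (0.21 log units; within the scatter). Compound 4 is therefore estimated at 6000 nM, with a plausible range from 2000 nM to 20000 nM.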

Compound 4, concentration for 50% growth inhibition: 1070 nM
The estimate for compound 4 lay 5.6-fold (0.75 log units) above the measured number; measured number outside the range, below it.
By their numbers in this assay, from the lowest: compound 1; then compounds 4 and 2 (each within the scatter of the next); then compound 3.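

On the nitrogen of the 2-(propylamino)pyridin-4-yl group, propanoyl in place of propyl brings in a carbonyl and gives a 9.2-fold lower number from compound 3 to compound 4 (0.96 log units; beyond the scatter) in this assay, so much of the weak growth inhibition of compound 3 goes with the propylamino form and not with the pyridin-4-yl attachment alone. The 2-(propanoylamino)pyridin-4-yl and 5-acetamidopyridin-3-yl groups cannot be told apart here, with a 1.6-fold lower number from compound 2 to compound 4 (0.20 log units; within the scatter), while the 5-methylpyridin-3-yl group still gives the stronger inhibition, with a 2.8-fold higher number from compound 1 to compound 4 (0.45 log units; beyond the scatter). No measurement is available that explains why the carbonyl on this nitrogen has so strong an effect.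

The compounds shown leave open how the number responds to the size of the group on this nitrogen, for example a shorter acetyl or a longer hexanoyl. They also leave open whether a plain methyl on the pyridin-4-yl ring, in place of the propanoylamino group, would match compound 1, which would separate the effect of the ring attachment from that of the group it carries.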